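The source may report more compounds than this note shows. Statements on the series, on what has been measured and on what is new or still open speak of the compounds shown alone.

Working notes on the series. Compound 2 `COc1ccc2nc(-c3ccc(N/C=C\C(=O)c4ccc(OC)c(F)c4)cc3)sc2c1` gives 500 nM in a functional assay on HeLa cells (Homo sapiens) for antiproliferative activity, read by sulforhodamine B assay, with a stated time of 48 h (a higher number here means a weaker inhibitor, a lower number a stronger inhibitor), the lowest number among the three measured compounds. Compound 1 `COc1cc(C(=O)/C=C\Nc2ccc(-c3nc4cc(OC)c(OC)c(OC)c4s3)cc2)c(Br)c(OC)c1OC` gives 6600 nM in this assay, and compound 3 `COc1ccc2nc(-c3ccc(N/C=C\C(=O)c4cc(OC)c(OC)c(OC)c4Br)cc3)sc2c1` gives 8020 nM; both gaps to compound 2 lie beyond the scatter. Within the data shown here, no two measured compounds differ in a single place, so no measured step is available to guide the next change. Compound 4 `COc1ccc2nc(-c3ccc(N/C=C\C(=O)c4ccc(OC)c([N+](=O)[O-])c4)cc3)sc2c1` carries the change (nitro in place of fluoro on an aromatic carbon). Nothing measured here speaks to this exchange, so the step is expected to be small, tending toward a somewhat higher number, possibly within the scatter. Compound 4 is therefore estimated at 800 nM in this assay, within 250 nM to 2500 nM. Expected, not measured, is a step of a 1.6-fold higher number from compound 2 to compound 4 (0.20 log units; within the scatter).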

Compound 4, half-maximal inhibitory concentration: 17600 nM
The estimate for compound 4 lay 22-fold (1.34 log units) below the measured number, outside the stated range (above it).
By their numbers in this assay, from the lowest: compound 2; then compounds 1 and 3 (each within the scatter of the next); then compound 4.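

On the 3-fluoro-4-methoxyphenyl ring, this position proves sensitive to the group it carries: nitro in place of fluoro gives a 35-fold higher number from compound 2 to compound 4 (1.55 log units; beyond the scatter) in this assay, the first single-place step measured in the series. The position therefore does not accept this exchange without a large change in the number. Nothing available explains the size of this step.

Open, on these data alone, is whether an amine, chloro or hydroxy at this position stays close to compound 2 or moves toward compound 4. Also open, as far as these compounds go, is whether the same exchange gives a comparable step on a different aryl ketone.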